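Extending a Carboxylic Acid Side Chain on the Shared Core

The source may hold more compounds than are shown below. What is called first, only, known or untested is meant among the compounds shown, and "the series" means these compounds.

Of the compounds shown here, two from this series have been measured in a physicochemical assay for solubility, read by HPLC, in simulated intestinal fluid, with a stated time of 3 days, at pH 6.8; a lower number here means a less soluble compound, a higher number a more soluble compound. Compound 1, with the structure `Cn1cc(C(=O)Nc2ccc(-c3ccccc3)c(C(F)(F)F)c2)c(=O)c2ccc(CO)cc21`, gives 27 ug/mL in this assay. Compound 2, with the structure `Cn1cc(C(=O)Nc2ccc(-c3ccccc3)c(C(F)(F)F)c2)c(=O)c2ccc(C(=O)O)cc21`, gives 48 ug/mL. Among the measured compounds shown here, the only measured step, a 1.8-fold higher number from compound 1 to compound 2 (0.25 log units; within the scatter), shows that these two numbers cannot be told apart with confidence; compound 2 stands as one of just two numbers, with compound 1 as its only neighbour.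

Compound 3, with the structure `Cn1cc(C(=O)Nc2ccc(-c3ccccc3)c(C(F)(F)F)c2)c(=O)c2ccc(CCC(=O)O)cc21`, differs from compound 2 by 2-carboxyethyl in place of carboxy on an aromatic carbon. For the measured compounds named here, no measured step covers this exact change. Going by the values given here, the one step at the same position of the shared core, from compound 1 to compound 2, was within the scatter, so the expectation for compound 3 is a step of a 1.2-fold lower number from compound 2 to compound 3 (0.08 log units; within the scatter) in this assay, with no clear direction beyond the scatter. Compound 3 is therefore estimated at 40 ug/mL, with a range from 15 ug/mL to 110 ug/mL.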

Compound 3, solubility: 200 ug/mL
Compound 3: middle estimate off by 5.0-fold (0.70 log units), on the low side; the measured number lies above the stated range.
By their numbers in this assay, from the lowest: compounds 1 and 2 (each within the scatter of the next); then compound 3.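

In this assay, this position on the shared core now shows a change beyond the scatter: 2-carboxyethyl in place of carboxy gives a 4.2-fold higher number from compound 2 to compound 3 (0.62 log units; beyond the scatter). Set against the hydroxymethyl group of compound 1, the same 2-carboxyethyl group gives a 7.4-fold higher number from compound 1 to compound 3 (0.87 log units; beyond the scatter), so compound 3 stands apart from both earlier compounds, which lie within the scatter of each other. No available measurement explains why the number differs at this position.

The compounds shown leave open whether a longer chain ending in a carboxylic acid would raise the number further, or whether the step depends on the chain itself or on its acid end. An amine at the end of the same chain, or a plain alkyl chain with no acid, would help tell these readings apart.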